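Phenyl for Dimethoxyphenyl on a Cyclopentenone Scaffold

The compounds below may be only part of what the source reports. "The series", "measured", "known", "first", "only" and "open" are said of these compounds alone.

Compounds measured so far:
compound 1, `COc1ccc(C2=C(c3cc(OC)c(OC)c(OC)c3)C(=O)CC2O[SiH2]C(C)(C)C)cc1OC`: > 100 ug/mL
compound 2, `COc1ccc(C2=C(c3cc(OC)c(OC)c(OC)c3)C(=O)C(O)C2)cc1`: < 1 ug/mL
compound 3, `COc1cc(C2=C(c3cc(C)c(OC)c(C)c3)C(OC(C)=O)CC2=O)cc(OC)c1OC`: > 100 ug/mL

This account concerns an ADME assay on KB cells (Homo sapiens) for cytotoxicity, read by MTT assay, with a stated time of 72 h (on this read-out higher numbers stand for weaker inhibition and lower numbers for stronger inhibition), and the move from compound 1 to compound 4. For compound 1 the value > 100 ug/mL is only a limit of the assay, not a number. Compound 3 also sits at a limit, > 100 ug/mL; these two share (the limit of > 100 ug/mL in this assay, at which 2 of the 3 values shown sit). Compound 2, by contrast, sits at the other limit, < 1 ug/mL, and is the single occupant of the limit of < 1 ug/mL in this assay, at which 1 of the 3 values shown sits. Among the compounds with values here, compound 1 thus stands with the weaker pair, and no step between two measured compounds that differ in one place is available to calibrate the change at hand.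

Compound 4, `COc1cc(C2=C(c3ccccc3)C(O[SiH2]C(C)(C)C)CC2=O)cc(OC)c1OC`, is not yet measured. It differs from compound 1 in one respect: phenyl in place of 3,4-dimethoxyphenyl on a double-bonded ring carbon. The large group next to the ring atom carrying the changed aryl is retained from compound 1.

Because compound 1 gives > 100 ug/mL, a limit, compound 4 is expected to remain at that limit too, with an expected step of a number no higher from compound 1 to compound 4 (the limit leaves the size open) of no size beyond the scatter. The estimate for compound 4 is 100 ug/mL, spanning 30 ug/mL to 300 ug/mL.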

Compound 4, half-maximal inhibitory concentration: > 100 ug/mL
Compound 4 ended at the assay's limit; the forecaster's own chance of this, stated with the estimate: 70%; the middle value lies on the limit itself.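

Compound 1 and compound 4 both rest at the same limit of this assay, and no step between them can be read: the limit of > 100 ug/mL in this assay, at which 3 of the 4 values shown sit.

The compounds shown leave open whether phenyl and 3,4-dimethoxyphenyl would differ at all on a compound whose value falls within the readable range of this assay.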